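Swapping fluoro for chloro on compound 2

This account rests on a few compounds, and the source may have more. Where it says the series, first, only, none or still open, it means among the compounds named here.

Measured values in an ADME assay on Vero cells (Chlorocebus sabaeus) for cytotoxicity, read by MTT assay, with a stated time of 72 h (on this read-out higher numbers stand for lower toxicity in this test and lower numbers for higher toxicity in this test), are these
Compound 1 `COc1ccc(/C=C(\C)C(=O)/C=C/c2ccccc2Cl)cc1` gives 74300 nM
Compound 2 `COc1ccc(/C=C(\C)C(=O)/C=C/c2ccc(F)cc2)cc1` gives 68100 nM
Compound 3 `CC/C(=C\c1ccc(Cl)cc1)C(=O)/C=C/c1ccccc1Br` gives 24400 nM

Compound 2 stands level with compound 1 within the scatter, and compound 3 gives a lower number than either. Compound 4 `COc1ccc(/C=C(\C)C(=O)/C=C/c2ccc(Cl)cc2)cc1` has not yet been measured. It is compound 2 with a single change, (chloro in place of fluoro on an aromatic carbon), which puts chloro in place of fluoro on an aromatic carbon, para to a large group.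

Among the compounds with values here, the only measured step that bears on this change, a 1.1-fold lower number from compound 1 to compound 2 (0.04 log units; within the scatter), is small, although it also exchanges one halogen-bearing phenyl for another. Within the data shown here, compound 3 is joined to the others by no such single step, so it offers no direct guide. With so small a step as the guide, the expected change, a 1.1-fold lower number from compound 2 to compound 4 (0.05 log units; within the scatter), in this assay stays within the scatter. Compound 4 is therefore estimated at 60000 nM with a range from 30000 nM to 115000 nM expected.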

Compound 4, half-maximal cytotoxic concentration: 87000 nM
For compound 4 the middle estimate is 1.5-fold (0.16 log units) below the measured one, and the stated range covers the measured number.
By their numbers in this assay, from the lowest: compound 3; then compounds 2, 1 and 4 (each within the scatter of the next).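

In this assay, the exchange at this place, on an aromatic carbon para to a large group, gives a 1.3-fold higher number from compound 2 to compound 4 (0.11 log units; within the scatter) and so does not separate chloro from fluoro. Within the data shown here, a second step, a 1.2-fold higher number from compound 1 to compound 4 (0.07 log units; within the scatter) with 4-chlorophenyl in place of 2-chlorophenyl, adds what the earlier compounds did not show: with the halogen held as chloro, moving from one named phenyl to the other also stays within the scatter, so these three compounds stand level whichever of these halogen-bearing phenyl groups they carry. Nothing available here accounts for this level reading. Going by these compounds, what remains open is whether a group of another kind at this place, such as an amine or a carboxylic acid, would stay level with these halogens. The compounds shown also do not say whether a second halogen on the same ring would do so.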